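A Methoxy for a Methyl on a Weak Sulfonamide

The source may report more compounds than this note shows. Statements on the series, on what has been measured and on what is new or still open speak of the compounds shown alone.

Compound 1 `Cc1ccc(S(=O)(=O)Nc2ccc(-c3nc4ccccc4o3)cc2)cc1` was tested in an assay on cells for inhibition of HSP60/HSP10 (Homo sapiens), with a stated time of 60 min; a higher number here means a weaker inhibitor, a lower number a stronger inhibitor. Here compound 1 gives only a limit, > 100000 nM, so no number is known for it. That limit is the point at which one of the three values shown sits (the limit of > 100000 nM in this assay, at which 1 of the 3 values shown sits). The two companions are measured as numbers: compound 2 `CS(=O)(=O)Nc1ccc(-c2nc3cc(NS(=O)(=O)c4ccc(Cl)s4)ccc3o2)cc1` gives 43000 nM in this assay, and compound 3 `O=S(=O)(Nc1ccc2oc(-c3ccccc3)nc2c1)c1cccc(O)c1` gives 76000 nM. All three share a core and a sulfonamide, and none of them inhibits strongly.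

Compound 4 `COc1ccccc1S(=O)(=O)Nc1ccc(-c2nc3ccccc3o2)cc1` differs from compound 1 in one place: 2-methoxyphenyl in place of 4-methylphenyl on a sulfonyl sulfur. Within the data shown here, no measured pair in this set shows what such a swap does, so there is no step to lean on. Since compound 1 sits at the limit, the only expectation that can be formed is that compound 4 stays near it, with the step of a number no higher from compound 1 to compound 4 (the limit leaves the size open) expected to be none beyond the scatter. Compound 4 is therefore estimated at 100000 nM, within a range from 30000 nM to 300000 nM, and it may well come back as a limit again.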

Compound 4, half-maximal inhibitory concentration: > 100000 nM
Compound 4 ended at the assay's limit (the forecaster's own chance of this, stated with the estimate: 60%); the middle value sits exactly at the limit.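

Compound 1 and compound 4 both stop at a limit of this assay rather than at a number, so no step can be read between them: (the limit of > 100000 nM in this assay, at which 2 of the 4 values shown sit). The compounds shown leave open whether 2-methoxyphenyl in place of 4-methylphenyl changes inhibition at all.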